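Swapping a Methoxyphenyl for a Difluorophenyl on the Core

The source may hold more compounds than are shown below. What is called first, only, known or untested is meant among the compounds shown, and "the series" means these compounds.

The measure here is a functional assay on HeLa cells (Homo sapiens) for inhibition, read by MTT assay, with a stated time of 24 h; on this read-out higher numbers stand for weaker inhibition and lower numbers for stronger inhibition. Compound 1, with the structure `CCOC(=O)C1=Cc2ccccc2OC1(OCc1cc(-c2ccc(OC)cc2)no1)C(F)(F)F`, reaches only a limit of this assay: in this assay compound 1 gives > 150000 nM, which is a limit and not a number. Compound 2, `COc1ccc(-c2cc(COC3(C(F)(F)F)Oc4ccccc4C=C3C(=O)O)on2)cc1`, also stops at a limit, giving > 150000 nM in this assay. Among the measured compounds shown here, the step that the two limits leave unreadable from compound 1 to compound 2 is therefore unreadable, and the limit of > 150000 nM in this assay, at which 2 of the 3 values shown sit, is the only evidence on it. For the measured compounds named here, compound 3, `CCOC(=O)C1=Cc2ccccc2OC1(OCc1cn(-c2ccc(F)c(Cl)c2)nn1)C(F)(F)F`, gives 22700 nM in this assay; it differs from compound 1 in more than one place, so no single step links them.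

The compound to be measured is compound 4, `CCOC(=O)C1=Cc2ccccc2OC1(OCc1cc(-c2ccc(F)cc2F)no1)C(F)(F)F`. It differs from compound 1 as follows: 2,4-difluorophenyl in place of 4-methoxyphenyl on an aromatic carbon. Going by the values given here, no measured step bears on this change, and compound 1 itself stands only at a limit. Compound 4 is expected to give 100000 nM in this assay, within 20000 nM to 300000 nM. The expected step of an at least 1.5-fold lower number from compound 1 to compound 4 (0.17 log units; that floor lies within the scatter) is therefore small and uncertain in direction.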

Compound 4, half-maximal inhibitory concentration: > 150000 nM
Compound 4: only a limit was reported (the forecaster's own chance of this, stated with the estimate: 55%); at least 1.5-fold (0.17 log units) between middle value and limit.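

Among the compounds shown here, compound 1 and compound 4 both stop at a limit in this assay, so no step between them can be read. The only evidence is that limit: the limit of > 150000 nM in this assay, at which 3 of the 4 values shown sit.

As far as these compounds go, whether 2,4-difluorophenyl in place of 4-methoxyphenyl changes inhibition at all, and in which direction, stays open.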